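This account rests on a few compounds, and the source may have more. Where it says the series, first, only, none or still open, it means among the compounds named here.

The series is built on the shared core of compound 1 `C=CCNC(=S)N/N=C/C=C/c1ccc([N+](=O)[O-])o1` and compound 2 `C=CCNC(=S)N/N=C/C=C/C=C/c1ccc([N+](=O)[O-])o1`, which differ from each other only in the chain. In an ADME assay on J774 cells (Mus musculus) for cytotoxicity, read by MTT assay, with a stated time of 48 h (a higher number here means a weaker inhibitor, a lower number a stronger inhibitor), compound 1 gives 200 uM. In this assay compound 2 gives only a limit, < 100 uM. Compound 2 thus stands at the limit of < 100 uM in this assay, at which 1 of the 2 values shown sits, without a number of its own, and the pair of compound 1 and compound 2 shows one number and one limit, nothing more. The next step leads to compound 3 `C=CCNC(=S)N/N=C/C=C/C=C/c1ccco1`; the change is hydrogen in place of nitro on an aromatic carbon, in words hydrogen in place of nitro on an aromatic carbon. Among the compounds with values here, no measured step of this kind exists. The step from compound 2 to compound 3 is expected to be an at least 1.5-fold higher number from compound 2 to compound 3 (0.17 log units; that floor lies within the scatter), towards weaker inhibition in this assay. Compound 3 is estimated at 150 uM, with a range from 50 uM to 400 uM.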

Compound 3, concentration for 50% inhibition: > 400 uM
Compound 3 gave a limit, no number; the forecaster's own chance of this, stated with the estimate: 30%; middle value at least 2.6-fold (0.42 log units) from the limit.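

The only step shown at this place, on an aromatic carbon next to the ring oxygen, replaces nitro with hydrogen and gives an at least 4.0-fold higher number from compound 2 to compound 3 (0.60 log units; beyond the scatter) in this assay; this is a floor for the step, not its measured size, and it points towards weaker inhibition once the nitro group leaves. The lower end of that step is a limit for compound 2, not a number: the limit of < 100 uM in this assay, at which 1 of the 3 values shown sits. The upper end is a limit for compound 3, also not a number: the limit of > 400 uM in this assay, at which 1 of the 3 values shown sits.

As far as these compounds go, whether another group at this place, such as a nitrile or an amine, would stay close to compound 2 or to compound 3 remains open. Also open, from the compounds shown here alone, are the exact size of this step and whether the same change on the shorter chain of compound 1 gives a comparable step.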